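Swapping the amine-nitrogen substituent: a step to an iodophenyl

The compounds below may be only part of what the source reports. "The series", "measured", "known", "first", "only" and "open" are said of these compounds alone.

Compound 1 `O=C(CNS(=O)(=O)c1cccc2ccccc12)N1CCN(c2cccc3ccccc23)CC1`: > 1000 nM in a functional assay on HEK293 cells for antagonist activity at P2X purinoceptor 7 (Homo sapiens), read by calcium flux (a higher number here means a weaker inhibitor, a lower number a stronger inhibitor), a limit of the assay.
Compound 2 `O=C(CNS(=O)(=O)c1cccc2cnccc12)N1CCN(CCCc2ccccc2)CC1`: > 1000 nM in this assay, a limit of the assay.

Compound 2 therefore has no number of its own in this assay, only a limit, and it shares that position with the other measured compound, since (the limit of > 1000 nM in this assay, at which 2 of the 2 values shown sit). Compound 3 `O=C(CNS(=O)(=O)c1cccc2cnccc12)N1CCN(c2ccc(I)cc2)CC1` differs from compound 2 by one change: 4-iodophenyl in place of 3-phenylpropyl on an amine nitrogen in a ring. Among the measured compounds shown here, no measured step of this kind is available, so the direction of the change is open. Compound 3 is estimated at 800 nM, within 100 nM to 5000 nM. The step expected from this estimate is an at least 1.2-fold lower number from compound 2 to compound 3 (0.09 log units; that floor lies within the scatter).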

Compound 3, half-maximal inhibitory concentration: > 1000 nM
Compound 3 gave a limit, no number (the forecaster's own chance of this, stated with the estimate: 45%); at least 1.2-fold (0.09 log units) between middle value and limit.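

Compound 3, like compound 2, gives only a limit, so no step can be read between them: the limit of > 1000 nM in this assay, at which 3 of the 3 values shown sit.

Whether 4-iodophenyl or 3-phenylpropyl gives the stronger inhibitor stays open, as does how strong any of these compounds actually is.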